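The compounds below may be only part of what the source reports. "The series", "measured", "known", "first", "only" and "open" are said of these compounds alone.

Values in a functional assay on HL-60 cells (Homo sapiens) for inhibition, read by MTT assay, with a stated time of 72 h; a higher number here means a weaker inhibitor, a lower number a stronger inhibitor:
- compound 1 `Cc1nc(-c2ccccc2F)c(C(=O)N2CCN(c3cc(Cl)ccc3C)CC2)o1`: 229 nM
- compound 2 `Cc1nc(-c2ccc(Cl)cc2)c(C(=O)N2CCN(c3cccc(C(=O)C(C)C)c3)CC2)o1`: "not active" (no number reported)
- compound 3 `CCc1nc(-c2ccc(F)cc2)c(C(=O)N2CCN(c3cccc(OC)c3)CC2)o1`: 411 nM

Not yet measured: compound 4 `C=C(C)c1cccc(N2CCN(C(=O)c3oc(C)nc3-c3ccccc3F)CC2)c1`.

Compound 1 stands level with compound 3, the two values lying within the scatter of each other, while compound 2 has no number to compare. Compound 4 keeps the core of compound 1 and changes one group on an amine nitrogen in a ring, with 3-(1-methylethenyl)phenyl in place of 5-chloro-2-methylphenyl on an amine nitrogen in a ring.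

Going by the values given here, no pair of measured compounds isolates this change, so the direction is tentative. Among the compounds with values here, the only guide is that the two compounds lacking 5-chloro-2-methylphenyl, which also differ elsewhere, are compound 3 at 411 nM and compound 2 at "not active" (no number reported). In this assay the expected step is a 2.2-fold higher number from compound 1 to compound 4 (0.34 log units; beyond the scatter), modest in size and towards a weaker inhibitor. The estimate for compound 4 is 500 nM, with an expected range of 140 nM to 1800 nM.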

Compound 4, half-maximal inhibitory concentration: "not active" (no number reported)
Compound 4 has no reported number here, and the estimate cannot be compared.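

In this assay, going by these compounds alone, compound 4 carries no number, so no step from compound 1 to compound 4 can be read. No evidence on a cause is available. The compounds shown leave open how 3-(1-methylethenyl)phenyl in place of 5-chloro-2-methylphenyl alone affects inhibition.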